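Working notes: methyl added to compound 2

The source may hold more compounds than are shown below. What is called first, only, known or untested is meant among the compounds shown, and "the series" means these compounds.

- compound 1 `Cc1ccc(NC(=O)CCc2cccc3c2B(O)OC3)cc1`: > 100000 nM
- compound 2 `O=C(CCc1cccc2c1B(O)OC2)Nc1cccc(Br)c1`: 20000 nM

For the measured compounds named here, in an ADME assay on WI-38 cells (Homo sapiens) for cytotoxicity, read by MTT assay, with a stated time of 72 h (a lower number here means a stronger inhibitor, a higher number a weaker inhibitor), compound 2 gives 20000 nM, the only actual number so far. Compound 1 gives > 100000 nM, which is a limit of the assay.

Compound 3 `Cc1ccc(NC(=O)CCc2cccc3c2B(O)OC3)cc1Br` differs from compound 2 as follows: methyl in place of hydrogen on an aromatic carbon. Going by the values given here, one measured step bears on this: an at least 5.0-fold lower number from compound 1 to compound 2 (0.69 log units; beyond the scatter). That step changes two groups at once, so it does not show which of them carries the shift. Compound 3 holds both the methyl and the bromo group, and a modest move towards a higher number in this assay is expected, possibly within the scatter. The expected change is a 1.5-fold higher number from compound 2 to compound 3 (0.18 log units; within the scatter). For compound 3 the estimated value is 30000 nM. The expected range for compound 3 runs from 10000 nM to 90000 nM.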

Compound 3, half-maximal inhibitory concentration: 15000 nM
For compound 3 the middle estimate is 2.0-fold (0.30 log units) above the measured one; the measured number falls inside the stated range.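

In this assay, methyl in place of hydrogen on an aromatic carbon, ortho to a bromo group, gives a 1.3-fold lower number from compound 2 to compound 3 (0.12 log units; within the scatter) and so makes no readable difference while the bromo group is present. With the methyl group held in place, adding the bromo group gives an at least 6.6-fold lower number from compound 1 to compound 3 (0.82 log units; beyond the scatter), which separates the two groups that were changed together in the earlier step and links the shift to the bromo group. On these data alone, the value of compound 1, > 100000 nM, is a limit of the assay and not a number, so the full size of this step stays open: the limit of > 100000 nM in this assay, at which 1 of the 3 values shown sits.

Open, as far as these compounds go, is how an amine or a carboxylic acid in place of the bromo group would read on this ring. From the compounds shown here alone, how a longer chain in place of the present amide linker would read also stays open.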